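The source may hold more compounds than are shown below. What is called first, only, known or untested is meant among the compounds shown, and "the series" means these compounds.

Compound 1 `COc1ccc(C(=O)n2c(-c3cn(C)c4ccccc34)nc3ccccc32)cc1OC` is measured in a functional assay on A549 cells (Homo sapiens) for inhibition, read by MTT assay, with a stated time of 24 h (on this read-out higher numbers stand for weaker inhibition of growth and lower numbers for stronger inhibition of growth), where compound 1 gives 3100 nM. Compound 2 `Cn1cc(-c2nc3ccccc3n2C(=O)c2ccccc2Br)c2ccccc21` gives 43200 nM in this assay, and the change that leads there, (2-bromophenyl in place of 3,4-dimethoxyphenyl on a carbonyl carbon), made a large step: a 14-fold higher number from compound 1 to compound 2 (1.14 log units; beyond the scatter). Compound 3 `COc1ccc2c(c1)c(-c1nc3ccccc3n1C(=O)c1ccc(OC)c(OC)c1)cn2C` differs from compound 1 by methoxy in place of hydrogen on an aromatic carbon, and in this assay compound 3 gives 2700 nM, a step of a 1.1-fold lower number from compound 1 to compound 3 (0.06 log units; within the scatter). Compound 4 `COc1ccc2c(c1)c(-c1nc3ccccc3n1C(=O)c1ccccc1Br)cn2C` is not yet measured; it differs from compound 3 by 2-bromophenyl in place of 3,4-dimethoxyphenyl on a carbonyl carbon, the same change, at the same place, as that from compound 1 to compound 2. Because the earlier step was a 14-fold higher number from compound 1 to compound 2 (1.14 log units; beyond the scatter), the step to compound 4 is expected to be similar, a 13-fold higher number from compound 3 to compound 4 (1.11 log units; beyond the scatter), with the shared cores differing only by methoxy in place of hydrogen on an aromatic carbon. Compound 4 is therefore estimated at 35000 nM, expected between 12000 nM and 100000 nM.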

Compound 4, concentration for 50% growth inhibition: 29500 nM
The estimate for compound 4 lay 1.2-fold (0.07 log units) above the measured number, and the stated range covers the measured number.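

In this assay, 2-bromophenyl in place of 3,4-dimethoxyphenyl on a carbonyl carbon gave an 11-fold higher number from compound 3 to compound 4 (1.04 log units; beyond the scatter), so the change carried over from one core to the other with much the same size: the same change on two cores in this assay, a 14-fold higher number (1.14 log units; beyond the scatter) from compound 1 to compound 2 and an 11-fold higher number (1.04 log units; beyond the scatter) from compound 3 to compound 4, 1.3-fold (0.11 log units) apart, within the scatter of two such steps. Methoxy in place of hydrogen on an aromatic carbon gave a 1.5-fold lower number from compound 2 to compound 4 (0.17 log units; within the scatter), and this step also agrees with its counterpart on the other core: the same change on two cores in this assay, a 1.1-fold lower number (0.06 log units; within the scatter) from compound 1 to compound 3 and a 1.5-fold lower number (0.17 log units; within the scatter) from compound 2 to compound 4, 1.3-fold (0.11 log units) apart, within the scatter of two such steps. This shows that the two changes behaved consistently across these four compounds, but it does not show that they would do so on any other core, nor why the number rises. The compounds shown leave open how an unsubstituted phenyl or a phenyl carrying an amine would behave on the carbonyl carbon. They also leave open whether a carboxylic acid or a longer chain in place of the methoxy would fit the same pattern.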